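This account rests on a few compounds, and the source may have more. Where it says the series, first, only, none or still open, it means among the compounds named here.

Compound 1 `Cc1ccc(C(=O)c2cc(F)c(OCC(=O)NNC(=O)c3ccc(=O)oc3)c(Cl)c2)cc1`: 21400 nM
Compound 2 `Cn1cnc(C(=O)NNC(=O)COc2c(F)cc(C(=O)c3ccc(F)cc3)cc2Cl)c1`: 40700 nM
Compound 3 `Cn1cnc(C(=O)NNC(=O)COc2c(F)cc(C(=O)c3ccc(Cl)cc3)cc2Cl)c1`: 45800 nM

All three were tested in a functional assay on A549 cells (Homo sapiens) for cytotoxicity, read by LDH release, with a stated time of 48 h; a lower number here means a stronger inhibitor, a higher number a weaker inhibitor. Compound 3 shows a higher number than compound 1, a gap beyond the scatter, and cannot be told apart from compound 2.

Compound 4 `Cc1ccc(C(=O)c2cc(F)c(OCC(=O)NNC(=O)c3cn(C)cn3)c(Cl)c2)cc1` differs from compound 3 in one place: methyl in place of chloro on an aromatic carbon, turning 4-chlorophenyl into 4-methylphenyl (methyl in place of chloro on an aromatic carbon). For the measured compounds named here, the one measured step at this same place is a 1.1-fold higher number from compound 2 to compound 3 (0.05 log units; within the scatter), with chloro in place of fluoro on an aromatic carbon. Going by the values given here, that step stayed small, but it swaps one halogen for another, and no measured step puts a methyl there, so the evidence is indirect. Compound 1 is linked to the others by no single-place step, so it serves only as a reason for a wider range.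

On the strength of that one small step, no change beyond the scatter is expected, and the estimate is a 1.2-fold lower number from compound 3 to compound 4 (0.08 log units; within the scatter). Compound 4 is expected at about 38000 nM, with an estimated range of 20000 nM to 70000 nM.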

Compound 4, half-maximal inhibitory concentration: 9100 nM
Compound 4: middle estimate off by 4.2-fold (0.62 log units), on the high side; the whole stated range lies above it.
By their numbers in this assay, from the lowest: compound 4; then compounds 1, 2 and 3 (each within the scatter of the next, the first and the last beyond it).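

In this assay, the place para to a large group proved sensitive after all: chloro and fluoro could not be told apart there, yet methyl in place of chloro gives a 5.0-fold lower number from compound 3 to compound 4 (0.70 log units; beyond the scatter) and methyl in place of fluoro gives a 4.5-fold lower number from compound 2 to compound 4 (0.65 log units; beyond the scatter) at the same place. The group on the carbonyl carbon counts as well, since the five-membered aromatic ring in place of the six-membered one gives a 2.4-fold lower number from compound 1 to compound 4 (0.37 log units; beyond the scatter) with the 4-methylphenyl kept. Nothing measured here explains why methyl parts from the two halogens at this place.

Still open, from the compounds shown here alone, is whether a longer chain such as ethyl, a methoxy group or an amine on that aromatic carbon would follow methyl or the halogens. Also open, going by these compounds, is whether the methyl gives a similar step when the six-membered ring of compound 1 stands on the carbonyl carbon.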